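The source may hold more compounds than are shown below. What is called first, only, known or untested is meant among the compounds shown, and "the series" means these compounds.

Measured compounds:
compound 1, `Cc1cccc(CN2CCC=C(CCC(=O)NO)C2=O)c1` — 8120 nM
compound 2, `COc1cccc(CN2CCC=C(CCC(=O)NO)C2=O)c1` — 3920 nM
compound 3, `O=C(CCC1=CCCN(CCCCc2cccc3ccccc23)C1=O)NO` — 1470 nM

All three numbers come from a functional assay on MDA-MB-231 cells (Homo sapiens) for inhibition, read by sulforhodamine B assay; on this read-out higher numbers stand for weaker inhibition of growth and lower numbers for stronger inhibition of growth. Compound 1 stands highest of the three. Its nearest neighbour is compound 2: a 2.1-fold lower number from compound 1 to compound 2 (0.32 log units; beyond the scatter). Compound 3 gives the lowest of the three numbers, but it differs from compound 1 in more than one place, so the two values are only compared as they stand.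

Compound 4, `Cc1ccccc1CN1CCC=C(CCC(=O)NO)C1=O`, has the same atoms as compound 1, joined differently: 2-methylphenyl in place of 3-methylphenyl on a saturated chain carbon bound to an amide-type nitrogen in a ring. Among the compounds with values here, the one measured single-place step, a 2.1-fold lower number from compound 1 to compound 2 (0.32 log units; beyond the scatter), swaps the group itself for another, whereas here the methyl merely moves to a different carbon of the same ring. Within the data shown here, no measured pair shows such a move, so nothing bears on it directly. The expectation is therefore a step of no size beyond the scatter, a 1.0-fold lower number from compound 1 to compound 4 (0.01 log units; within the scatter), with the range widened for the lack of any guiding step. For compound 4 the estimate in this assay is 8000 nM, between 3000 nM and 20000 nM.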

Compound 4, concentration for 50% growth inhibition: 4920 nM
Compound 4: middle estimate off by 1.6-fold (0.21 log units), on the high side; low and high end bracket the measured number.
By their numbers in this assay, from the lowest: compound 3; then compounds 2, 4 and 1 (each within the scatter of the next, the first and the last beyond it).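

In this assay, moving the methyl from 3-methylphenyl to 2-methylphenyl on the saturated chain carbon bound to an amide-type nitrogen in a ring gives a 1.7-fold lower number from compound 1 to compound 4 (0.22 log units; within the scatter). Within the data shown here, this is the first view of a positional move on this aromatic ring, as the earlier single-place comparison changed the group itself, and for this one pair the methyl's location does not separate the two values beyond the scatter. No available evidence accounts for the result or explains how it relates to the methoxy change.

On these data alone, whether the methoxy group of compound 2 would behave the same way if moved around the ring remains open. Also open, as far as these compounds go, are the reading for an amine or a carboxylic acid on that ring and the separate effects of the longer chain and naphthalene-bearing group of compound 3.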